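Swapping a Phenyl Ring for Pyridine in a Hydrazone Series

The source may report more compounds than this note shows. Statements on the series, on what has been measured and on what is new or still open speak of the compounds shown alone.

Compound 2 `CC1CCC(=NNc2cc(Cl)ccc2O)c2ncc(C(=O)O)c(=O)n21` carries a 5-chloro-2-hydroxyphenyl on an amine nitrogen whose other neighbour is a double-bonded nitrogen. In a functional assay on the whole organism with Rattus norvegicus as the target (on this read-out higher numbers stand for an effect only at larger amounts of compound and lower numbers for an effect already at smaller amounts), compound 2 reaches only the limit > 100 umol/kg, so no number is known for it, only a limit. Its neighbour compound 1 `Cc1cccc(NN=C2CCC(C)n3c2ncc(C(=O)O)c3=O)c1C` differs in having 2,3-dimethylphenyl in place of that ring. In this assay compound 1 also stops at the limit > 100 umol/kg. The step that the two limits leave unreadable from compound 1 to compound 2 therefore cannot be read, as both compounds share (the limit of > 100 umol/kg in this assay, at which 2 of the 2 values shown sit).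

Among the compounds with values here, compound 3 `CC1CCC(=NNc2cccnc2)c2ncc(C(=O)O)c(=O)n21` is the next change: pyridin-3-yl in place of 5-chloro-2-hydroxyphenyl on an amine nitrogen Of the measured steps only the one from compound 1 to compound 2 bears on a change of this ring, and its size is hidden by the two limits. Within the data shown here, there is thus no measured step to set an expectation of size or direction. Compound 3 is expected to sit at 150 umol/kg, between 40 umol/kg and 600 umol/kg. The expected step that the limit leaves unreadable from compound 2 to compound 3 is therefore no more than a placeholder, with the most likely outcome a further limit.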

Compound 3, dose for 50% inhibition: > 320 umol/kg
Compound 3 was reported as a limit; the forecaster's own chance of this, stated with the estimate: 70%; middle value at least 2.1-fold (0.32 log units) away from the limit.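

In this assay compound 3 also gives only a limit, > 320 umol/kg. Within the data shown here, as compound 1 and compound 2 stop at limits too, no step among compound 1, compound 2 and compound 3 can be read. The compounds shown leave open what dose any of them needs for the effect, and how their rings rank.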